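This account rests on a few compounds, and the source may have more. Where it says the series, first, only, none or still open, it means among the compounds named here.

Measured so far in an ADME assay on J774 cells (Mus musculus) for cytotoxicity; on this read-out lower numbers stand for an effect already at smaller amounts and higher numbers for an effect only at larger amounts of compound:
- Compound 1 `CCCCc1cc2c(=O)c(C#N)c[nH]c2cc1OCCOc1ccccc1`: > 20000 nM (a limit)
- Compound 2 `CCCCc1cc2c(=O)c(CC)c[nH]c2cc1OCCOc1ccccc1`: 360 nM
- Compound 3 `CCCCc1cc2c(=O)c(C(=O)OC)c[nH]c2cc1OCCOc1ccccc1`: > 20000 nM (a limit)

Compound 3 has no exact number, only the limit > 20000 nM. It is not alone in this: the series shows (the limit of > 20000 nM in this assay, at which 2 of the 3 values shown sit).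

Compound 4 `CCCCc1cc2c(=O)c(C(=O)NC)c[nH]c2cc1OCCOc1ccccc1` differs from compound 3 in one place, with methylamino in place of methoxy on a carbonyl carbon. The same difference can be read as methoxycarbonyl to methylcarbamoyl.

Going by the values given here, no measured step makes this exact exchange, so the evidence is indirect. Putting ethyl in place of cyano gave a large step, an at least 55-fold lower number from compound 1 to compound 2 (1.74 log units; beyond the scatter). Putting methoxycarbonyl in place of ethyl gave a large step back, an at least 55-fold higher number from compound 2 to compound 3 (1.74 log units; beyond the scatter). Between the two limits nothing can be read: a step that the two limits leave unreadable from compound 1 to compound 3. Only compound 2, which has ethyl, gives a true number, and compound 4 keeps the carbonyl of compound 3. A step beyond the usual scatter in this assay is therefore not expected, in either direction, and compound 4 may well reach the limit too.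

The expected change is a number no higher from compound 3 to compound 4 (the limit leaves the size open). For compound 4 the estimated value is 20000 nM, with an expected range from 5000 nM to 60000 nM.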

Compound 4, half-maximal effective concentration: > 20000 nM
Compound 4: only a limit was reported; the forecaster's own chance of this, stated with the estimate: 65%; the middle value sits exactly at the limit.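

In this assay compound 4 gives > 20000 nM, which is a limit of the assay and not a number. Set against the ethyl group, the only one here with a true number, the methylcarbamoyl group gives an at least 55-fold higher number from compound 2 to compound 4 (1.74 log units; beyond the scatter), so this second carbonyl group on the aromatic carbon, now with methylamino in place of methoxy, also fails to bring back a measurable effect. The steps among compound 1, compound 3 and compound 4 cannot be read, and so nothing separates the nitrile, the methoxycarbonyl and the methylcarbamoyl groups, while compound 2 with its ethyl group stands alone against them: the limit of > 20000 nM in this assay, at which 3 of the 4 values shown sit.

The compounds shown leave open whether a true number on this read-out needs a plain carbon chain at this aromatic carbon, which a methyl or a propyl group in place of ethyl would begin to answer. They also leave open whether a carboxylic acid or an aminomethyl group in the same place would sit at the limit or give a number of its own.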